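The source may hold more compounds than are shown below. What is called first, only, known or untested is meant among the compounds shown, and "the series" means these compounds.

Measured so far:
- compound 1, `CCN1CCN(c2cc(C)c3cc(NC(=O)c4cc(Cl)cc(Cl)c4)ccc3n2)CC1`: 2660 nM
- compound 2, `CCN1CCN(c2cc(C)c3cc(NC(=O)c4cccc(Br)c4)ccc3n2)CC1`: 13300 nM

Within the data shown here, in a functional assay on SK-BR-3 cells (Homo sapiens) for antiproliferative activity, read by MTT assay, with a stated time of 72 h (on this read-out higher numbers stand for weaker inhibition and lower numbers for stronger inhibition), compound 2 gives the higher of the two numbers in hand; the only neighbour is compound 1, and the step of a 5.0-fold higher number from compound 1 to compound 2 (0.70 log units; beyond the scatter) shows that this one swap of the halogen pattern already cost a modest amount beyond the scatter.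

The next compound, compound 3, `CCN1CCN(c2cc(C)c3cc(NC(=O)c4ccccc4Cl)ccc3n2)CC1`, changes the same ring again: 2-chlorophenyl in place of 3-bromophenyl on a carbonyl carbon. Among the measured compounds shown here, no measured pair shows a chlorine in this position of the ring, so the only step that bears on it is a 5.0-fold higher number from compound 1 to compound 2 (0.70 log units; beyond the scatter), which tells how much a change of halogen pattern on this ring can move this assay but not in which direction the present one will go. The expectation is therefore a step of no clear direction, a 1.3-fold lower number from compound 2 to compound 3 (0.12 log units; within the scatter), with a wide range. Compound 3 is estimated at 10000 nM (range 3000 nM to 40000 nM).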

Compound 3, half-maximal inhibitory concentration: > 50000 nM
Compound 3 was reported as a limit; the forecaster's own chance of this, stated with the estimate: 20%; middle value at least 5.0-fold (0.69 log units) away from the limit.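

Compound 3 is reported in this assay only as a limit, not as a number: the limit of > 50000 nM in this assay, at which 1 of the 3 values shown sits.

The swap to 2-chlorophenyl on the carbonyl carbon gives an at least 3.7-fold higher number from compound 2 to compound 3 (0.57 log units; beyond the scatter) and also an at least 18-fold higher number from compound 1 to compound 3 (1.27 log units; beyond the scatter) as the comparison with the 3,5-dichlorophenyl compound. The earlier pair showed only a shift between two measurable values, whereas this ring can now be seen to carry the series all the way to the limit of the assay. Both the halogen and its place on the ring change in this step, so the two contributions stay joined.

Open, as far as these compounds go, is whether 3-chlorophenyl or 2-bromophenyl would separate them. Also open, from the compounds shown here alone, is how an unsubstituted phenyl, or a ring bearing a methoxy group or an amine, would read here.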